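The source may report more compounds than this note shows. Statements on the series, on what has been measured and on what is new or still open speak of the compounds shown alone.

Measured so far:
compound 1 `CCCCNC(=S)N/N=C\c1c[nH]c2ccccc12` — > 100000 nM
compound 2 `Fc1cccc(F)c1NC(=S)N/N=C\c1c[nH]c2ccccc12` — > 100000 nM

Both numbers come from an ADME assay on KB cells (Homo sapiens) for cytotoxicity, read by MTT assay, with a stated time of 44 h; a higher number here means a weaker inhibitor, a lower number a stronger inhibitor. For compound 1 the entry > 100000 nM is a limit of the assay, not a measured number. The same is true of compound 2, whose > 100000 nM is also a limit. Compound 1 therefore stands at the edge of what this assay reports, and on the numbers shown nothing separates it from compound 2; both sit at the limit of > 100000 nM in this assay, at which 2 of the 2 values shown sit.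

The step to compound 3 `Cc1ccccc1NC(=S)N/N=C\c1c[nH]c2ccccc12` alters one group on the shared core of compound 1: 2-methylphenyl in place of butyl on an amide-type nitrogen. Within the data shown here, no step between measured compounds is available as a guide. Because compound 1 and compound 2 both rest at the limit of > 100000 nM in this assay, at which 2 of the 2 values shown sit, the expected step is a number no higher from compound 1 to compound 3 (the limit leaves the size open), none beyond the scatter. Compound 3 is expected to give 100000 nM in this assay, within a range from 40000 nM to 300000 nM, most likely again reported only as a limit.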

Compound 3, half-maximal inhibitory concentration: > 100000 nM
Compound 3 gave a limit, no number (the forecaster's own chance of this, stated with the estimate: 85%); the middle value sits exactly at the limit.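

No step from compound 1 to compound 3 can be read in this assay, as each result is a limit and not a number: the limit of > 100000 nM in this assay, at which 3 of the 3 values shown sit.

The compounds shown leave open whether the group on the amide-type nitrogen changes the result in this assay at all.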